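The source may hold more compounds than are shown below. What is called first, only, known or untested is meant among the compounds shown, and "the series" means these compounds.

Three analogues sharing one core have been tested in a functional assay on LoVo cells (Homo sapiens) for antiproliferative activity, read by MTT assay, with a stated time of 48 h; a lower number here means a stronger inhibitor, a higher number a weaker inhibitor. Compound 1 `CC1(C)CC(NC(=O)c2ccc(Nc3ncc([N+](=O)[O-])c(NC4CCCC4)n3)cc2)CC(C)(C)N1[O]` gives 41200 nM, compound 2 `CCN1CCN(c2nc(Nc3ccc(C(=O)NC4CC(C)(C)N([O])C(C)(C)C4)cc3)ncc2[N+](=O)[O-])CC1` gives 39700 nM, and compound 3 `CC1(C)CC(NC(=O)c2ccc(Nc3ncc([N+](=O)[O-])c(N4CCN(c5ccc(F)cc5)CC4)n3)cc2)CC(C)(C)N1[O]` gives 27800 nM. Of these three numbers compound 2's is the second highest, nearest to compound 1 and furthest from compound 3, though all three lie within the scatter of one another. The step of a 1.0-fold lower number from compound 1 to compound 2 (0.02 log units; within the scatter) and the step of a 1.4-fold lower number from compound 2 to compound 3 (0.15 log units; within the scatter) both swap the group on an aromatic carbon of the core and both stay within the scatter. Compound 4 `Cc1cc(Nc2nc(Nc3ccc(C(=O)NC4CC(C)(C)N([O])C(C)(C)C4)cc3)ncc2[N+](=O)[O-])n[nH]1` alters that same group: (5-methyl-1H-pyrazol-3-yl)amino in place of 4-ethylpiperazin-1-yl on an aromatic carbon. Both earlier steps bear on this change and neither moved the number, so for compound 4 a step of about a 1.0-fold lower number from compound 2 to compound 4 (0.02 log units; within the scatter) in this assay is expected, nothing beyond the scatter. Compound 4 is therefore estimated at 38000 nM, within 14000 nM to 100000 nM.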

Compound 4, half-maximal inhibitory concentration: > 100000 nM
Compound 4 was reported as a limit; the forecaster's own chance of this, stated with the estimate: 10%; middle value at least 2.6-fold (0.42 log units) from the limit.
By their numbers in this assay, from the lowest: compounds 3, 2 and 1 (each within the scatter of the next). At a limit, above all of these: compound 4.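

In this assay compound 4 gives > 100000 nM, which is a limit and not a number. Among the compounds shown here, the position had so far tolerated every swap within the scatter, but the pyrazolylamino group gives an at least 2.5-fold higher number from compound 2 to compound 4 (0.40 log units; beyond the scatter) and, against the cyclopentylamino group, an at least 2.4-fold higher number from compound 1 to compound 4 (0.38 log units; beyond the scatter). The group on this aromatic carbon therefore can matter, and both steps are bounded on one side only: the limit of > 100000 nM in this assay, at which 1 of the 4 values shown sits.

The compounds shown leave open whether the methyl on the pyrazole plays any part in this step. They also leave open whether a phenylamino group here would behave like the (5-methyl-1H-pyrazol-3-yl)amino group.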